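Aryltriazole nucleoside analogues: cytotoxicity on A549 cells

The source may report more compounds than this note shows. Statements on the series, on what has been measured and on what is new or still open speak of the compounds shown alone.

Measured so far:
compound 1 `CCS[C@@H]1[C@H](SCC)[C@@H](Cn2cc(-c3ccc(C)cc3)nn2)O[C@H]1n1ccc(=O)[nH]c1=O`: 6780 nM
compound 2 `CCS[C@@H]1[C@H](SCC)[C@@H](Cn2cc(-c3ccc(F)cc3)nn2)O[C@H]1n1cc(C)c(=O)[nH]c1=O`: >= 100000 nM
compound 3 `CCS[C@@H]1[C@H](SCC)[C@@H](Cn2cc(-c3ccccc3C(F)(F)F)nn2)O[C@H]1n1cc(C)c(=O)[nH]c1=O`: 7230 nM

In a functional assay on A549 cells (Homo sapiens) for cytotoxicity, read by MTT assay, with a stated time of 72 h (a higher number here means that more compound is needed for the effect, a lower number that less compound is needed), compound 3 gives 7230 nM, the highest of the two numbers available. Its nearest neighbour is compound 1 with 6780 nM, which lies within the scatter of it. Compound 2 reaches only a limit of the assay, >= 100000 nM (the limit of >= 100000 nM in this assay, at which 1 of the 3 values shown sits).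

Compound 4 `CCS[C@@H]1[C@H](SCC)[C@@H](Cn2cc(-c3ccc(C)cc3)nn2)O[C@H]1n1cc(C)c(=O)[nH]c1=O` is not yet measured. It differs from compound 3 as follows: 4-methylphenyl in place of 2-(trifluoromethyl)phenyl on an aromatic carbon.

Among the measured compounds shown here, only one measured step touches the aryl group on the triazole: an at least 13-fold lower number from compound 2 to compound 3 (1.14 log units; beyond the scatter). That step exchanged a para-substituted phenyl for the 2-(trifluoromethyl)phenyl, and the number fell sharply. The step to compound 4 reverses this direction, bringing back a para-substituted phenyl, now 4-methylphenyl. Against that, compound 1 bears the same 4-methylphenyl group on a different core and gives 6780 nM, a number close to that of compound 3.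

Weighing both, the number for compound 4 is expected to rise moderately in this assay, by about a 2.8-fold higher number from compound 3 to compound 4 (0.44 log units; beyond the scatter), with a real chance that only a limit is reached. The estimate for compound 4 is 20000 nM, within 5000 nM to 100000 nM.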

Compound 4, half-maximal effective concentration: 12300 nM
Compound 4: the middle estimate sits 1.6-fold (0.21 log units) above what was measured; the range from low to high includes it.
By their numbers in this assay, from the lowest: compounds 1, 3 and 4 (each within the scatter of the next). At a limit, above all of these: compound 2.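

In this assay, 4-methylphenyl in place of 2-(trifluoromethyl)phenyl on the triazole carbon gives a 1.7-fold higher number from compound 3 to compound 4 (0.23 log units; within the scatter), so these two aryl groups cannot be told apart here and the earlier large step is not specific to 2-(trifluoromethyl)phenyl; methyl in place of hydrogen on the core gives a 1.8-fold higher number from compound 1 to compound 4 (0.26 log units; within the scatter), so that core change has no readable effect in this pair either. With the core held constant, methyl in place of fluoro on the phenyl ring gives an at least 8.1-fold lower number from compound 2 to compound 4 (0.91 log units; beyond the scatter), which makes the 4-fluorophenyl compound the one that stands apart among the compounds shown, while the other three lie close together. The value for compound 2 is a limit of the assay and not a number, so the true size of this step stays unknown: the limit of >= 100000 nM in this assay, at which 1 of the 4 values shown sits.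

From the compounds shown here alone, whether the gap belongs to fluoro alone remains open, as a 4-chlorophenyl group or a phenyl ring carrying an amine or a carboxylic acid would be needed to test it. Also open, going by these compounds, is whether 4-fluorophenyl reaches a limit on the core of compound 1.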